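The source may hold more compounds than are shown below. What is called first, only, known or untested is meant among the compounds shown, and "the series" means these compounds.

In a functional assay on HCT-116 cells (Homo sapiens) for inhibition, read by MTT assay, with a stated time of 48 h (on this read-out lower numbers stand for stronger inhibition and higher numbers for weaker inhibition), three compounds with a shared core have been measured: compound 1 `CCCCC(=O)N(Cc1ccc(OC)c(O)c1)c1cc(OC)c(OC)c(OC)c1` gives 170 nM while compound 2 `COc1ccc(CN(C(C)=O)c2cc(OC)c(OC)c(OC)c2)cc1O` gives 270 nM and compound 3 `C#CC(=O)N(Cc1ccc(OC)c(O)c1)c1cc(OC)c(OC)c(OC)c1` gives 310 nM so that compound 3 stands within the scatter of both others. Compound 4 `C/C=C/C=C/C(=O)N(Cc1ccc(OC)c(O)c1)c1cc(OC)c(OC)c(OC)c1` carries penta-1,3-dien-1-yl in place of ethynyl on the carbonyl carbon bound to the amide-type nitrogen (penta-1,3-dien-1-yl in place of ethynyl on a carbonyl carbon). Two measured steps change the group at this place: a 1.8-fold higher number from compound 1 to compound 3 (0.26 log units; within the scatter) with ethynyl in place of butyl and a 1.1-fold higher number from compound 2 to compound 3 (0.06 log units; within the scatter) with ethynyl in place of methyl. For the measured compounds named here, no measured compound yet carries penta-1,3-dien-1-yl. In this assay no step beyond the scatter is therefore expected. The estimated step is a 1.4-fold lower number from compound 3 to compound 4 (0.15 log units; within the scatter) and stays inside the scatter. Compound 4 is estimated at 220 nM with an expected range from 90 nM to 550 nM in this estimate.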

Compound 4, half-maximal inhibitory concentration: 180 nM
The estimate for compound 4 lay 1.2-fold (0.09 log units) above the measured number, within the range that was stated.
By their numbers in this assay, from the lowest: compounds 1, 4, 2 and 3 (each within the scatter of the next).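

In this assay, for the compounds shown here, penta-1,3-dien-1-yl on the carbonyl carbon brings double bonds to this place for the first time, yet every step to it stays within the scatter: (a 1.7-fold lower number from compound 3 to compound 4 (0.24 log units; within the scatter)) against ethynyl, (a 1.5-fold lower number from compound 2 to compound 4 (0.18 log units; within the scatter)) against methyl and (a 1.1-fold higher number from compound 1 to compound 4 (0.02 log units; within the scatter)) against butyl. Among these four compounds, then, neither the triple bond, the double bonds nor the saturated chains set any compound apart. Nothing shown here offers an explanation for this. From the compounds shown here alone, whether an amine, a carboxylic acid or a phenyl ring at this place would give a step beyond the scatter remains open.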